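The source may hold more compounds than are shown below. What is called first, only, known or untested is meant among the compounds shown, and "the series" means these compounds.

Compound 1 `Cn1c(/C=C/C(=O)c2ccccc2)cc(Br)c1Br` was tested in a functional assay on Caco-2 cells (Homo sapiens) for cytotoxicity, read by MTT assay, with stated times of 6 h and 48 h; on this read-out higher numbers stand for weaker inhibition and lower numbers for stronger inhibition. In this assay compound 1 gives >= 100000 nM, which is a limit of the assay and not a number. Compound 2 `Cn1c(/C=C/C(=O)c2ccc[nH]2)cc(Br)c1Br` differs from compound 1 in that it carries 1H-pyrrol-2-yl in place of phenyl on a carbonyl carbon. In this assay compound 2 gives >= 100000 nM, again only a limit. Compound 3 `O=C(/C=C/c1cc(Br)c(Br)[nH]1)c1ccccc1` differs from compound 1 by hydrogen in place of methyl on an aromatic nitrogen. In this assay compound 3 gives >= 100000 nM, also a limit. The step that the two limits leave unreadable from compound 1 to compound 3 cannot be sized because of the limit of >= 100000 nM in this assay, at which 3 of the 3 values shown sit. Compound 4 `O=C(/C=C/c1cc(Br)c(Br)[nH]1)c1ccc[nH]1` has not yet been measured; it differs from compound 2 by hydrogen in place of methyl on an aromatic nitrogen. This is the same kind of change as from compound 1 to compound 3, with one difference around the place: the ring atom bears a group of 9 heavy atoms rather than a large group. The step from compound 2 to compound 4 is expected to be a number no higher from compound 2 to compound 4 (the limit leaves the size open), resting on the step that the two limits leave unreadable from compound 1 to compound 3 and on (the limit of >= 100000 nM in this assay, at which 3 of the 3 values shown sit). Compound 4 is therefore estimated at 100000 nM in this assay, most probably reported again only as a limit.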

Compound 4, half-maximal inhibitory concentration: >= 100000 nM
Compound 4: a limit, no number; the forecaster's own chance of this, stated with the estimate: 85%; the middle value sits exactly at the limit.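

Within the data shown here, compound 4, like compound 2, gives only a limit, so the step between them cannot be read, because no compound here yields a number: the limit of >= 100000 nM in this assay, at which 4 of the 4 values shown sit. The compounds shown leave open whether hydrogen in place of methyl on the aromatic nitrogen changes the inhibition at all in this assay.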